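Chloro to Sulfanyl on an Aryl Arm: Expected Cytotoxicity

The source may hold more compounds than are shown below. What is called first, only, known or untested is meant among the compounds shown, and "the series" means these compounds.

Measured compounds:
compound 1 `Cc1nc2c3ccccc3ccc2c2nc3c(ccc4ccccc43)c(-c3cccnc3)c12`: 34200 nM in a functional assay on HCT-116 cells (Homo sapiens) for cytotoxicity, read by MTT assay, with a stated time of 48 h; on this read-out lower numbers stand for stronger inhibition and higher numbers for weaker inhibition
compound 2 `Cc1nc2c3ccccc3ccc2c2nc3c(ccc4ccccc43)c(-c3ccccc3Cl)c12`: 48200 nM in this assay
compound 3 `Cc1nc2c3ccccc3ccc2c2nc3c(ccc4ccccc43)c(-c3ccccc3S)c12`: not yet measured in this assay

Compound 2 sits at the highest of the two numbers shown, but the gap to compound 1 is one the scatter covers, a 1.4-fold higher number from compound 1 to compound 2 (0.15 log units; within the scatter), so the two compounds cannot be told apart on potency. Compound 3 differs from compound 2 in a single place: sulfanyl in place of chloro on an aromatic carbon. Among the compounds with values here, no measured pair shows this exchange of chloro for sulfanyl; the only step on hand replaces one whole aryl group with another and stays within the scatter. With nothing pointing in either direction, the change is expected to leave the number roughly where it stands, within the scatter: a 1.1-fold lower number from compound 2 to compound 3 (0.03 log units; within the scatter). Compound 3 is therefore estimated at 45000 nM, with a range from 18000 nM to 110000 nM.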

Compound 3, half-maximal inhibitory concentration: 1420 nM
The estimate for compound 3 lay 32-fold (1.50 log units) above the measured number; measured number below the stated range.
By their numbers in this assay, from the lowest: compound 3; then compounds 1 and 2 (each within the scatter of the next).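

In this assay, within the data shown here, this position proves sensitive to a change of a single heavy atom: sulfanyl in place of chloro, ortho to a large group, gives a 34-fold lower number from compound 2 to compound 3 (1.53 log units; beyond the scatter) and so separates two compounds that differ by only that group. Starting from the other arm, 2-sulfanylphenyl in place of pyridin-3-yl gives a 24-fold lower number from compound 1 to compound 3 (1.38 log units; beyond the scatter) and reaches the same low number, whereas the earlier exchange of one aryl arm for another stayed within the scatter. Nothing available explains why the sulfanyl group has this effect.

The compounds shown cannot tell whether the free sulfanyl hydrogen matters, since they include no methylsulfanyl, hydroxyl or amine group at this place. They also leave open whether sulfanyl would give a similar number elsewhere on the ring or on a different core.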